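Bromo for chloro on compound 3

A few compounds are considered here, and "the series" means these few. Any claim that something is new, unique, unknown or untested is made for them only; others in the source may bear on it.

In a functional assay on KG-1 cells (Homo sapiens) for cytotoxicity, read by luminescence and CellTiter-Glo, with a stated time of 3 days (on this read-out higher numbers stand for weaker inhibition and lower numbers for stronger inhibition), compound 1 `N#Cc1ccc(NC(=O)c2cc(Cl)ccc2O)c(Cl)c1` gives 860 nM and compound 2 `O=C(Nc1ccc(C(F)(F)F)cc1)c1cc(Cl)ccc1O` gives 740 nM while compound 3 `N#Cc1ccc(NC(=O)c2cc(Cl)ccc2O)cc1` gives 1860 nM as the highest of the three numbers. Compound 4 `N#Cc1ccc(NC(=O)c2cc(Br)ccc2O)cc1` differs from compound 3 in one place bromo in place of chloro on an aromatic carbon with bromo in place of chloro on an aromatic carbon para to a hydroxy group. Going by the values given here, two measured steps bear on it only indirectly: a 2.2-fold higher number from compound 1 to compound 3 (0.34 log units; beyond the scatter) and a 2.5-fold higher number from compound 2 to compound 3 (0.40 log units; beyond the scatter) are both modest and neither of them changes this chloro. Among the compounds with values here, an estimated 1.2-fold lower number from compound 3 to compound 4 (0.09 log units; within the scatter) is therefore expected, no larger than those steps and within the scatter. For compound 4 the expected value is 1500 nM with 750 nM to 2800 nM as its estimated range.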

Compound 4, half-maximal inhibitory concentration: 1290 nM
For compound 4 the middle estimate is 1.2-fold (0.07 log units) above the measured one, within the range that was stated.
By their numbers in this assay, from the lowest: compounds 2, 1, 4 and 3 (each within the scatter of the next, the first and the last beyond it).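

The earlier steps shown here left this chloro untouched; here, para to a hydroxy group, this assay gives a 1.4-fold lower number from compound 3 to compound 4 (0.16 log units; within the scatter) when bromo takes its place. Compound 3 and compound 4 therefore cannot be told apart on this read-out, so at this position the two halogens are interchangeable within the scatter. No measurement on hand accounts for this result. On these data alone, whether a group other than a halogen, such as an amine, a methoxy group or a carboxylic acid, would be matched here remains open. So does whether bromo would give the same result alongside the second chloro of compound 1.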